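The source may hold more compounds than are shown below. What is called first, only, known or untested is meant among the compounds shown, and "the series" means these compounds.

Measured in an ADME assay on S9 fraction from liver (Rattus norvegicus) for metabolic stability, read by LC-MS, using NADPH, with a stated time of 30 min; a lower number here means that less of the compound is left, a higher number that more of the compound is left:
Compound 1 `CCCCCCCCc1ccc(OCC(=O)Cn2nnc(C)n2)cc1`: < 5%, which is a limit of the assay
Compound 2 `CCCCCCCCc1ccc(OCC(=O)Cn2nnc(-c3ccc(C(=O)OC)cc3)n2)cc1`: 64%
Compound 3 `CCCCCCCCc1ccc(OCC(=O)Cn2nnc(-c3cccnc3)n2)cc1`: 12%

Of the two values that are numbers rather than a limit, compound 3 has the lower one. Compound 4 `CCCCCCCCc1ccc(OCC(=O)Cn2nnc(Cc3ccccc3)n2)cc1` differs from it in one place: benzyl in place of pyridin-3-yl on an aromatic carbon. Changes at this same place gave a number at least 59 percentage points higher from compound 1 to compound 2 (beyond the scatter), a number at least 7 percentage points higher from compound 1 to compound 3 (that floor lies within the scatter) and a number 52 percentage points lower from compound 2 to compound 3 (beyond the scatter). The large steps both involve compound 2, whose group is not close to benzyl, so neither sets the size expected here. Only a small rise in this assay is therefore expected, with no clear step beyond the scatter. The estimated step is a number 6 percentage points higher from compound 3 to compound 4 (within the scatter). For compound 4 the expected value is 18%, with an estimated range from 5% to 42%.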

Compound 4, percent of the compound remaining: < 5%
Compound 4 was reported as a limit; the forecaster's own chance of this, stated with the estimate: 15%; middle value at least 13 percentage points away from the limit.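

In this assay compound 4 gives < 5%, which is a limit of the assay. Benzyl in place of 4-(methoxycarbonyl)phenyl gives a number at least 59 percentage points lower from compound 2 to compound 4 (beyond the scatter), so a six-membered aromatic ring at this place does not by itself go with a high number: compound 3 and compound 4 also carry one. Benzyl in place of pyridin-3-yl gives a number at least 7 percentage points lower from compound 3 to compound 4 (that floor lies within the scatter), which does not separate these two groups.

Going by these compounds, the step between compound 1 and compound 4 cannot be read because both sit at the same limit: the limit of < 5% in this assay, at which 2 of the 4 values shown sit. Still open is whether a plain phenyl, or a carboxylic acid in place of the methoxycarbonyl group of compound 2, would keep a high number.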